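Halogen swap on the aryl piperazine of a thiophene core

The source may report more compounds than this note shows. Statements on the series, on what has been measured and on what is new or still open speak of the compounds shown alone.

Compound 2 `Nc1scc(CN2CCN(c3ccc(Cl)cc3F)CC2)c1C(=O)c1ccc(Cl)cc1` gives -81% in a functional assay on CHO cells with adenosine receptor A1 (Homo sapiens) as the target, read by cAMP accumulation and immunoassay, with a stated time of 6 min, tested at 10 uM (a higher number here means a weaker effect of the compound at the concentration tested, a lower number a stronger effect), the lowest of the three numbers measured, so the strongest effect of the set. Compound 1 `Nc1scc(CN2CCN(c3ccc(F)cc3Cl)CC2)c1C(=O)c1ccc(Cl)cc1` gives -70%, and compound 3 `Nc1scc(CN2CCN(c3cccnc3)CC2)c1C(=O)c1ccc(Cl)cc1` gives -23%. The step from compound 1 to compound 2, where the two halogens on the phenyl ring trade places, is a number 11 percentage points lower from compound 1 to compound 2 (beyond the scatter), a modest shift. The step from compound 2 to compound 3, where the phenyl ring gives way to pyridin-3-yl, is a number 58 percentage points higher from compound 2 to compound 3 (beyond the scatter), a large loss of effect.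

Compound 4 `Nc1scc(CN2CCN(c3cc(F)ccc3F)CC2)c1C(=O)c1ccc(Cl)cc1` differs from compound 2 as follows: 2,5-difluorophenyl in place of 4-chloro-2-fluorophenyl on an amine nitrogen in a ring. The ring stays an aromatic carbon ring bearing two halogens, as in the step from compound 1 to compound 2, and unlike the step to compound 3. A modest step, most likely toward a somewhat higher number, is therefore expected, with a number 11 percentage points higher from compound 2 to compound 4 (beyond the scatter). Compound 4 is estimated at -70%, within -85% to -50%.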

Compound 4, a percentage reported as activity, at one concentration (the size of the read-out at that concentration, not a potency): -80%
For compound 4 the middle estimate is 10 percentage points above the measured one, and the stated range covers the measured number.
By their numbers in this assay, from the lowest: compounds 2, 4 and 1 (each within the scatter of the next, the first and the last beyond it); then compound 3.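

In this assay, 2,5-difluorophenyl in place of 4-chloro-2-fluorophenyl gives a number 1 percentage points higher from compound 2 to compound 4 (within the scatter) and so shows that this place on the ring nitrogen accepts a phenyl ring carrying two fluorines and no chlorine. Set against 2-chloro-4-fluorophenyl, the same group gives a number 10 percentage points lower from compound 1 to compound 4 (within the scatter) even though compound 1 and compound 2 lie beyond the scatter of each other, so compound 4 cannot be ordered against either of them. With pyridin-3-yl as the starting point, the change gives a number 57 percentage points lower from compound 3 to compound 4 (beyond the scatter) and thereby extends the large gap to a third dihalogenated phenyl ring, but nothing available explains these differences.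

Whether any halogen is needed remains open, since a plain phenyl ring is not among the compounds shown. So does the outcome with a methoxy group or a nitrile on that ring.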